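The source may report more compounds than this note shows. Statements on the series, on what has been measured and on what is new or still open speak of the compounds shown alone.

Compound 1 `CCC(C)COc1cccc2ccc(N)nc12` gives 36 nM in an assay on cells with melanin-concentrating hormone receptor 1 (Homo sapiens) as the target, read by radioligand binding; a lower number here means a stronger inhibitor, a higher number a weaker inhibitor; compound 2 `CCCCCOc1cccc2ccc(N)nc12` gives 580 nM in this assay.

Compound 2 stands at the higher of the two numbers, the weaker inhibitor, with a 16-fold higher number from compound 1 to compound 2 (1.21 log units; beyond the scatter). Compound 3 `CCCOc1cccc2ccc(N)nc12` differs from compound 2 by hydrogen in place of ethyl on a saturated chain carbon, three bonds along the chain from an oxygen on an aromatic ring, so the pentyl becomes a propyl. Going by the values given here, the single measured step swapped a branched chain for a straight one; no step tracks a shorter chain, so it bears only loosely here. A further rise beyond the scatter is expected, as a 2.6-fold higher number from compound 2 to compound 3 (0.41 log units; beyond the scatter). Compound 3 is estimated at 1500 nM, within 300 nM to 8000 nM.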

Compound 3, half-maximal inhibitory concentration: 1100 nM
Beside the measured number, compound 3's estimate is 1.4-fold (0.13 log units) above it; the measured number falls inside the stated range.
By their numbers in this assay, from the lowest: compound 1; then compounds 2 and 3 (each within the scatter of the next).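

Taking the pentyl down to a propyl gives no clear change in this assay: a 1.9-fold higher number from compound 2 to compound 3 (0.28 log units; within the scatter). Across these straight chains, length therefore makes no difference that can be read, while the branched chain remains clearly apart, with a 31-fold higher number from compound 1 to compound 3 (1.49 log units; beyond the scatter). No supporting measurement explains why this pattern appears.

As far as these compounds go, it remains open whether a longer chain such as hexyl, or a chain carrying an amine, would give a number close to that of compound 1 or one close to those of the straight chains.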